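Phenyl swap on the compound 1 scaffold: working notes

A few compounds are considered here, and "the series" means these few. Any claim that something is new, unique, unknown or untested is made for them only; others in the source may bear on it.

Measured so far in a functional assay on MCF7 cells (Homo sapiens) for cytotoxicity, read by MTT assay, with a stated time of 72 h; on this read-out lower numbers stand for stronger inhibition and higher numbers for weaker inhibition:
- Compound 1 `Cn1c(=O)c2c(nc(NCc3ccccc3)n2C[C@@H](O)COc2ccc(Cl)cc2)n(C)c1=O`: 3500 nM
- Compound 2 `Cc1nc(C)c(C(=O)OC[C@H]2CCCO2)c(-c2ccccc2C(F)(F)F)c1C(=O)O`: 10800 nM

Of these two numbers, compound 1 at 3500 nM holds the lower one, and compound 2 at 10800 nM lies above it by more than the usual scatter. Among the measured compounds shown here, the two compounds do not differ in a single place, so the pair gives no measured step that could guide a prediction.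

The next compound to be read is compound 3 `Cc1ccccc1OC[C@H](O)Cn1c(NCc2ccccc2)nc2c1c(=O)n(C)c(=O)n2C`. It keeps the core of compound 1 and carries one change: 2-methylphenyl in place of 4-chlorophenyl on an oxygen on a saturated carbon. In words, 2-methylphenyl stands in place of 4-chlorophenyl on an oxygen on a saturated carbon, so 4-chlorophenoxy becomes 2-methylphenoxy.

For the measured compounds named here, with no measured precedent for this swap, the only anchor is compound 1 at 3500 nM, and the prediction remains loose. In this assay, a small shift towards a higher number is expected, probably not beyond the scatter. The expected change is a 1.4-fold higher number from compound 1 to compound 3 (0.15 log units; within the scatter). Compound 3 is estimated at 5000 nM, with an expected range from 2000 nM to 14000 nM.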

Compound 3, half-maximal inhibitory concentration: 1540 nM
Compound 3: middle estimate off by 3.2-fold (0.51 log units), on the high side; the measured number lies below the stated range.
By their numbers in this assay, from the lowest: compound 3; then compound 1; then compound 2.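

In this assay, among the compounds shown here, the step of a 2.3-fold lower number from compound 1 to compound 3 (0.36 log units; beyond the scatter) is the first measured step, and it shows that the group on this oxygen can change the number by more than the scatter, with 2-methylphenyl in place of 4-chlorophenyl giving the lower number. The two groups match in what is counted for them: the same number of heavy atoms, one six-membered aromatic ring of carbon only, no hydrogen-bond donors or acceptors and no net charge, so the step rests on the change from 4-chlorophenyl to 2-methylphenyl alone, and it shows that chlorine is not needed at this position to hold the number of compound 1. No measurement at hand explains the direction or the size of this step.

This single step does not separate the exchange of chlorine for methyl from the change of ring position, a question that 4-methylphenyl or 2-chlorophenyl at the same place would address. Also open, from the compounds shown here alone, is how the number responds to a phenyl ring carrying an amine or a carboxylic acid, or to a longer chain between this oxygen and the ring.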